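A larger group on the aromatic nitrogen of compound 3

The compounds below may be only part of what the source reports. "The series", "measured", "known", "first", "only" and "open" are said of these compounds alone.

Measured so far:
compound 1 `CCCCCCCCN(C)C(=O)Cn1cc(Cc2cnc(=O)n(C)c2)c(=O)nc1SCc1ccc(F)cc1` gives 19%
compound 2 `CCCCCCCCN(C)C(=O)Cn1cc(Cc2cnc(=O)n(CC)c2)c(=O)nc1SCc1ccc(F)cc1` gives 5%
compound 3 `CCCCCCCCCCCCN(C)C(=O)Cn1cc(Cc2cnc(=O)n(C)c2)c(=O)nc1SCc1ccc(F)cc1` gives 32%

These three compounds were tested in a functional assay on a cell-free system (plasma, Oryctolagus cuniculus) for inhibition of platelet-activating factor acetylhydrolase (Homo sapiens), tested at 100 nM; on this read-out lower numbers stand for less inhibition and higher numbers for more inhibition at the one concentration tested (going by the name of the read-out). Compound 3 stands highest of the three numbers, with compound 1 nearest and compound 2 furthest. Compound 4 `CCCCCCCCCCCCN(C)C(=O)Cn1cc(Cc2cnc(=O)n(CC(=O)N3CCOCC3)c2)c(=O)nc1SCc1ccc(F)cc1` has not yet been measured. It differs from compound 3 in one place: (morpholin-4-yl)carbonyl in place of hydrogen on a saturated chain carbon bound to an aromatic nitrogen. Among the measured compounds shown here, only one measured step bears on this place: going from compound 1 to compound 2, where a methyl replaced a hydrogen there, the step was a number 14 percentage points lower from compound 1 to compound 2 (beyond the scatter). Adding a still larger group at the same place in compound 4 is therefore expected to lower inhibition, by a step of about a number 14 percentage points lower from compound 3 to compound 4 (beyond the scatter). Compound 4 is expected to give 18%, within a range from 5% to 32%.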

Compound 4, a percentage reported as inhibition, at one concentration (the size of the read-out at that concentration, not a potency): 30%
Estimate against measurement, compound 4: 12 percentage points below; the range from low to high includes it.
By their numbers in this assay, from the lowest: compound 2; then compound 1; then compounds 4 and 3 (each within the scatter of the next).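

In this assay, a group of this size at this place leaves the number within the scatter: (morpholin-4-yl)carbonyl in place of hydrogen gives a number 2 percentage points lower from compound 3 to compound 4 (within the scatter). The methyl step at the same place, a number 14 percentage points lower from compound 1 to compound 2 (beyond the scatter), therefore does not show that larger groups here always mean less inhibition, although that step was read on the shorter chain. Nothing measured here accounts for the difference between these two steps.

A carboxylic acid or an amine on this carbon could still read differently. From the compounds shown here alone, it also remains open whether (morpholin-4-yl)carbonyl would give the same result on the shorter chain of compound 1.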